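This account rests on a few compounds, and the source may have more. Where it says the series, first, only, none or still open, it means among the compounds named here.

Measured in an ADME assay on HEK293 cells (Homo sapiens) for cytotoxicity, read by reporter gene assay and resazurin assay, with a stated time of 48 h; a lower number here means that less compound is tolerated, a higher number that more compound is tolerated:
- compound 1 `COc1ccccc1C(=O)Nc1ccc(Sc2nc3ccccc3s2)c(Cl)c1`: > 100000 nM (a limit)
- compound 2 `COc1c(Br)cccc1C(=O)Nc1ccc(Sc2nc3ccccc3s2)c(Cl)c1`: > 100000 nM (a limit)
- compound 3 `O=C(Nc1ccc(Sc2nc3ccccc3s2)c(Cl)c1)c1cc(Br)ccc1O`: 45000 nM

Compound 3 is the only one of the three with an actual number. The other two stand at the limit of > 100000 nM in this assay, at which 2 of the 3 values shown sit.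

Compound 4 `O=C(Nc1ccc(Sc2nc3ccccc3s2)c(Cl)c1)c1ccccc1O` comes from compound 3 by a single change: hydrogen in place of bromo on an aromatic carbon. This is hydrogen in place of bromo on an aromatic carbon, para to a hydroxy group, so 5-bromo-2-hydroxyphenyl becomes 2-hydroxyphenyl.

For the measured compounds named here, the one measured swap of the same kind, bromo in place of hydrogen, is a step that the two limits leave unreadable from compound 1 to compound 2, and it sets no size. Two further steps end at compound 3: an at least 2.2-fold lower number from compound 1 to compound 3 (0.34 log units; beyond the scatter) and an at least 2.2-fold lower number from compound 2 to compound 3 (0.34 log units; beyond the scatter). Both are lower bounds, and neither isolates the bromo, since each also changes the methoxy group.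

Compound 4 keeps the hydroxy group of compound 3 but lacks the bromo, as compound 1 does. Going by the values given here, a shift toward the higher numbers of this assay is therefore expected, though only a small one, given that an at least 2.2-fold lower number from compound 1 to compound 3 (0.34 log units; beyond the scatter) is the sole guide to its size. The step expected is a 1.6-fold higher number from compound 3 to compound 4 (0.19 log units; within the scatter). Compound 4 may also return only a limit. For compound 4 the estimate is 70000 nM, with an expected range of 30000 nM to 100000 nM.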

Compound 4, half-maximal cytotoxic concentration: 64000 nM
For compound 4 the middle estimate is 1.1-fold (0.04 log units) above the measured one, and the stated range covers the measured number.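

In this assay, the step for hydrogen in place of bromo, on an aromatic carbon para to a hydroxy group, can now be read directly, which compound 1 and compound 2 did not allow: it is a 1.4-fold higher number from compound 3 to compound 4 (0.15 log units; within the scatter) with the hydroxy group held constant. The bromo at this position therefore shows no effect beyond the scatter, and compound 3 and compound 4 stand level in this assay. For the compounds shown here, without bromo, hydrogen in place of methyl on the oxygen gives an at least 1.5-fold lower number from compound 1 to compound 4 (0.19 log units; that floor lies within the scatter), and the change with bromo also leaving gives an at least 1.5-fold lower number from compound 2 to compound 4 (0.19 log units; that floor lies within the scatter), so neither of these floors establishes a real difference, unlike the floors of the earlier steps ending at compound 3.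

As far as these compounds go, compound 1 and compound 2 are both recorded only as limits, so the step between them cannot be read and the true size of the steps from them stays open: the limit of > 100000 nM in this assay, at which 2 of the 4 values shown sit. Also open, from the compounds shown here alone, is whether the flat bromo step holds for chloro, an amine or a carboxylic acid at this position, or for bromo when methoxy replaces the hydroxy group.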